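The source may hold more compounds than are shown below. What is called first, only, known or untested is meant among the compounds shown, and "the series" means these compounds.

Working notes on the sulfonamide series.

Compound 1 `CCN(CC)C(=O)CN(c1ccc(C)cc1)S(=O)(=O)c1cccc(Cl)c1` is the reference point. In a functional assay on CHO cells for inhibition of Orexin/Hypocretin receptor type 1 (Homo sapiens), read by FLIPR and calcium flux (a lower number here means a stronger inhibitor, a higher number a weaker inhibitor), compound 1 gives > 10000 nM, which is a limit of the assay and not a number. For the measured compounds named here, compound 2 `CCN(CC)C(=O)CN(c1cc(N(CC)CC)ccc1Cl)S(=O)(=O)c1ccc(OC)c(OC)c1` is the only other measured member; in this assay compound 2 gives > 10000 nM, again a limit. Going by the values given here, both values therefore sit at the limit of > 10000 nM in this assay, at which 2 of the 2 values shown sit, so no measured step between compounds exists and nothing about the size of any change can be read from the data so far.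

Compound 3 `CCN(CC)C(=O)CN(c1ccc(C)cc1)S(=O)(=O)c1ccc(C#N)cc1` is the next compound to be measured in this assay. It differs from compound 1 by 4-cyanophenyl in place of 3-chlorophenyl on a sulfonyl sulfur. With compound 1 at the limit, a step beyond the scatter is not expected; compound 3 is estimated to remain weak, most likely again reported as a limit. Compound 3 is expected at 15000 nM, with a range from 4000 nM to 60000 nM. The step that the limit leaves unreadable from compound 1 to compound 3 is thus estimated as essentially none.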

Compound 3, half-maximal inhibitory concentration: > 10000 nM
Compound 3 gave a limit, no number; the forecaster's own chance of this, stated with the estimate: 70%; the middle value lies beyond the limit too.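

For the compounds shown here, compound 3, like compound 1, gives a limit and not a number, so no step from compound 1 to compound 3 can be read in this assay: the limit of > 10000 nM in this assay, at which 3 of the 3 values shown sit. The compounds shown leave open which change to the shared core, if any, would give a measurable value in this assay.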